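From Hydroxy to Fluoro in an Antiproliferative Pair

This account rests on a few compounds, and the source may have more. Where it says the series, first, only, none or still open, it means among the compounds named here.

In a functional assay on MIA PaCa-2 cells (Homo sapiens) for antiproliferative activity, read by sulforhodamine B assay, with a stated time of 48 h (a higher number here means a weaker inhibitor, a lower number a stronger inhibitor), compound 1 (`COc1cc(OC)c2sc(-c3ccc(N/C=C\C(=O)c4ccc(OC)c(O)c4)c(C)c3)nc2c1`) gives 22100 nM and compound 2 (`COc1ccc(C(=O)/C=C\Nc2ccc(-c3nc4cc(OC)c(OC)c(OC)c4s3)cc2C)cc1O`) gives 15400 nM. Within the data shown here, these are the only two measured compounds, and the difference between them is a 1.4-fold lower number from compound 1 to compound 2 (0.16 log units; within the scatter), so the two cannot be told apart. Among the measured compounds shown here, compound 2 therefore stands within the scatter of the one compound it can be compared with.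

Compound 3 (`COc1ccc(C(=O)/C=C\Nc2ccc(-c3nc4cc(OC)c(OC)c(OC)c4s3)cc2C)cc1F`) differs from compound 2 at a single place: fluoro in place of hydroxy on an aromatic carbon. This is fluoro in place of hydroxy on an aromatic carbon, which turns 3-hydroxy-4-methoxyphenyl into 3-fluoro-4-methoxyphenyl.

For the measured compounds named here, the only measured step is methoxy in place of hydrogen on an aromatic carbon, and it involves neither hydroxy nor fluoro. Going by the values given here, no measured step replaces the hydroxy group, so the data give no direction for this change and only a weak guide to its size. The expectation in this assay is thus no shift beyond the scatter, with an estimated 1.0-fold lower number from compound 2 to compound 3 (0.01 log units; within the scatter). For compound 3 the expected value is 15000 nM, with an estimated range of 5000 nM to 40000 nM.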

Compound 3, half-maximal inhibitory concentration: 1800 nM
Compound 3: the middle estimate sits 8.3-fold (0.92 log units) above what was measured; the measured number lies below the stated range.
By their numbers in this assay, from the lowest: compound 3; then compounds 2 and 1 (each within the scatter of the next).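

In this assay, the place held by hydroxy in the 3-hydroxy-4-methoxyphenyl group proves responsive to substitution: fluoro in place of hydroxy gives an 8.6-fold lower number from compound 2 to compound 3 (0.93 log units; beyond the scatter), the only step shown that lies beyond the scatter, whereas methoxy in place of hydrogen on the shared core gave a 1.4-fold lower number from compound 1 to compound 2 (0.16 log units; within the scatter). The change is small in count, one heavy atom for one heavy atom on an aromatic carbon ortho to a methoxy group, with the one hydrogen-bond donor and one hydrogen-bond acceptor counted for hydroxy absent from fluoro, so a single-atom exchange at this place is enough to move the number beyond the scatter. No measurement shown here explains why the exchange has this effect.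

The compounds shown leave open whether the lower number is particular to fluoro or would also appear with another group at this place, such as chloro, an amine or a nitrile. They also leave open whether the same exchange would give a step of similar size on the core of compound 1.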